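Pyrazoline series: acyl to sulfonyl on the ring nitrogen

The source may report more compounds than this note shows. Statements on the series, on what has been measured and on what is new or still open speak of the compounds shown alone.

Measured compounds:
compound 1 `CN(C)c1ccc(C2CC(c3ccc(-n4cncn4)cc3)=NN2)cc1`, -3.3%
compound 2 `CN(C)c1ccc(C2CC(c3ccc(-n4ccnc4)cc3)=NN2)cc1`, 0.1%
compound 3 `CN1CCN(c2ccc(C3=NN(C(=O)c4ccc(F)cc4)C(c4ccc(N(C)C)cc4)C3)cc2)CC1`, 32.2%

In a functional assay on NCI-H1975 cells (Homo sapiens) for inhibition, read by sulforhodamine B assay, tested at 10 uM (a higher number here means more inhibition at the concentration tested (going by the name of the read-out), a lower number less inhibition), compound 3 stands highest of the three; compound 2 and compound 1 lie far below it, beyond the scatter. For the measured compounds named here, the single measured step, a number 3.4 percentage points higher from compound 1 to compound 2 (within the scatter), concerns a change elsewhere on the core and is within the scatter, so it says nothing about the ring nitrogen of compound 3.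

Compound 4 `CN1CCN(c2ccc(C3=NN(S(=O)(=O)c4ccc(F)cc4)C(c4ccc(N(C)C)cc4)C3)cc2)CC1` differs from compound 3 by (4-fluorophenyl)sulfonyl in place of (4-fluorophenyl)carbonyl on an amine nitrogen in a ring. Going by the values given here, no measured step touches this position, so there is no basis for expecting a shift beyond the scatter in this assay; the expected step is a number 2.2 percentage points lower from compound 3 to compound 4 (within the scatter). For compound 4 the estimate in this assay is 30%, expected between 10% and 50%.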

Compound 4, a percentage reported as inhibition, at one concentration (the size of the read-out at that concentration, not a potency): 95.7%
For compound 4 the middle estimate is 65.7 percentage points below the measured one; measured number outside the range, above it.
By their numbers in this assay, from the lowest: compounds 1 and 2 (each within the scatter of the next); then compound 3; then compound 4.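

In this assay the substituent on the amine nitrogen in a ring proves decisive, with (4-fluorophenyl)sulfonyl in place of (4-fluorophenyl)carbonyl giving a number 63.5 percentage points higher from compound 3 to compound 4 (beyond the scatter) in a single pair. For the compounds shown here, the only earlier step, a number 3.4 percentage points higher from compound 1 to compound 2 (within the scatter), lay within the scatter at another place, so this is the first large change seen. No measurement here accounts for the gain.

The compounds shown leave open whether a methylsulfonyl or unsubstituted phenylsulfonyl group on the same nitrogen would hold this level. A single tested concentration also gives no potency.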